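The source may hold more compounds than are shown below. What is called first, only, known or untested is meant among the compounds shown, and "the series" means these compounds.

Measured compounds:
compound 1 `Cc1cc(Nc2ccn(Cc3ccccc3)n2)n2nc(SCc3ccc(Br)cc3)nc2n1` – > 50000 nM
compound 2 `Cc1cc(Nc2cc(-c3ccccc3)[nH]n2)n2nc(SCc3cccc(Br)c3)nc2n1` – 8900 nM
compound 3 `COc1ccc(Cn2ccc(Nc3cc(C)nc4nc(SCc5ccc(Br)cc5)nn34)n2)cc1` – > 50000 nM

In a functional assay on PC-9 cells (Homo sapiens) for inhibition, read by MTT assay, with a stated time of 72 h (a lower number here means a stronger inhibitor, a higher number a weaker inhibitor), compound 1 gives > 50000 nM, a limit of the assay. Compound 3 likewise gives > 50000 nM, also a limit. Going by the values given here, compound 2 gives 8900 nM, the only number in the set. The step that the two limits leave unreadable from compound 1 to compound 3 cannot be read because both ends sit at the limit of > 50000 nM in this assay, at which 2 of the 3 values shown sit.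

Compound 4 `Cc1cc(Nc2cc(-c3ccccc3)[nH]n2)n2ncnc2n1` differs from compound 2 by hydrogen in place of (3-bromobenzyl)sulfanyl on an aromatic carbon. Among the compounds with values here, no measured step touches this position, so nothing measured bears on it directly. Removing so large a part of compound 2 is expected to cost activity, so the step of a 3.4-fold higher number from compound 2 to compound 4 (0.53 log units; beyond the scatter) is estimated as a loss. For compound 4 the estimate in this assay is 30000 nM, ranging from 9000 nM to 60000 nM.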

Compound 4, half-maximal inhibitory concentration: > 50000 nM
Compound 4 gave a limit, no number (the forecaster's own chance of this, stated with the estimate: 40%); middle value at least 1.6-fold (0.22 log units) from the limit.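

In this assay, going by these compounds alone, the first readable step at this position, on an aromatic carbon between two ring nitrogen atoms, is an at least 5.6-fold higher number from compound 2 to compound 4 (0.74 log units; beyond the scatter) with hydrogen in place of (3-bromobenzyl)sulfanyl. With the phenyl-bearing amine side of compound 2 held fixed, the measurable activity therefore depends on this group. Compound 4 gives a limit, not a number, so the size of the step is only a lower bound: the limit of > 50000 nM in this assay, at which 3 of the 4 values shown sit.

On these data alone, whether a methylsulfanyl or an amine on this carbon would keep a measurable value stays open. Also open, as far as these compounds go, is which part of the group counts: the sulfur, the benzene ring or the bromine.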